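This account rests on a few compounds, and the source may have more. Where it says the series, first, only, none or still open, it means among the compounds named here.

The study covers three thiazolidinedione and indole amides that were tested in a functional assay on RAW264.7 cells (Mus musculus) for inhibition, read by microscopy and resazurin assay, with a stated time of 72 h (on this read-out higher numbers stand for weaker inhibition and lower numbers for stronger inhibition), together with a fourth compound that has not yet been through it.

Compound 1 has the structure `C=CCONC(=O)CN1C(=O)S/C(=C\c2ccc(C(=O)N[C@@H](CC(C)C)C(=O)OC)cc2)C1=O`. In this assay compound 1 gives > 128000 nM, which is a limit of the assay rather than a number. Compound 2 has the structure `C=CCONC(=O)CN1C(=O)S/C(=C\c2ccc(C(=O)N[C@H](C(=O)OC)C(C)C)cc2)C1=O`. In this assay compound 2 reaches only the limit > 128000 nM. Compound 1 and compound 2 differ in one place, (isobutyl in place of isopropyl on a saturated chain carbon bound to an amide-type nitrogen and a carbonyl carbon), and the step this makes in this assay is a step that the two limits leave unreadable from compound 2 to compound 1; with both values sitting at the limit, its size cannot be read.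

Compound 3 has the structure `C=CCONC(=O)Cn1cc(C(=O)NCC(=O)N[C@H](C(=O)O)C(C)C)c2ccccc21`, built on a different core from compound 2; the difference between the two cores is not broken down here. In this assay compound 3 likewise gives > 128000 nM, a limit and not a number. All three measured compounds therefore share (the limit of > 128000 nM in this assay, at which 3 of the 3 values shown sit).

Compound 4, still to be measured, has the structure `C=CCONC(=O)Cn1cc(C(=O)NCC(=O)N[C@@H](CC(C)C)C(=O)O)c2ccccc21`. It differs from compound 3 by isobutyl in place of isopropyl on a saturated chain carbon bound to an amide-type nitrogen and a carbonyl carbon, the same change that separates compound 2 from compound 1, made on the same place.

The step from compound 3 to compound 4 in this assay is expected to be a step that the limit leaves unreadable from compound 3 to compound 4, because the same change between compound 2 and compound 1 left both partners at the limit (the limit of > 128000 nM in this assay, at which 3 of the 3 values shown sit). Compound 4 is therefore expected to give 150000 nM in this assay, with the estimate spanning 60000 nM to 400000 nM, and most likely to be reported again only as a limit.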

Compound 4, half-maximal inhibitory concentration: > 128000 nM
Compound 4: a limit, no number; the forecaster's own chance of this, stated with the estimate: 85%; the middle value lies beyond the limit too.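

In this assay compound 4 gives > 128000 nM, a limit and not a number. No step can be read between compound 3 and compound 4, because both sit at the limit: the limit of > 128000 nM in this assay, at which 4 of the 4 values shown sit.

The compounds shown leave open how strongly any of the four inhibits in this assay, and whether isobutyl in place of isopropyl changes that on either core.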